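Replacing a furan ring with a cyanophenyl group

The source may report more compounds than this note shows. Statements on the series, on what has been measured and on what is new or still open speak of the compounds shown alone.

Of the compounds shown here, three have so far been measured in a functional assay for agonist activity at G protein-coupled receptor 88 (Homo sapiens), read by HTRF and cAMP accumulation; on this read-out lower numbers stand for an effect already at smaller amounts and higher numbers for an effect only at larger amounts of compound. Compound 1 `N[C@@H](CC1CCCCC1)CN(C(=O)[C@@H]1C[C@H]1c1ccccc1)c1ccc(-c2ccccc2)cc1` gives 1.7 nM in this assay. Compound 2 `CC[C@H](C)[C@H](N)CN(C(=O)[C@@H]1C[C@H]1c1cccc(OC)c1)c1ccc(-c2ccccc2)cc1` gives 3000 nM, and compound 3 `CC(C)C[C@H](N)CN(C(=O)[C@@H]1C[C@H]1c1ccccc1)c1ccc(-c2ccoc2)cc1` gives 2000 nM. Compound 3 therefore stands second highest of the three numbers. Its nearest neighbour is compound 2, whose value lies within the usual scatter of it, so no order between these two can be drawn; compound 1 lies far lower, well beyond the scatter. Compound 1 and compound 2 each differ from compound 3 in more than one place. Within the data shown here, no step resting on a single structural change exists among the measured compounds.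

Compound 4 `CC(C)C[C@H](N)CN(C(=O)[C@@H]1C[C@H]1c1ccccc1)c1ccc(-c2ccc(C#N)cc2)cc1` has not yet been measured. It differs from compound 3 in one place: 4-cyanophenyl in place of furan-3-yl on an aromatic carbon.

Compound 1 carries a six-membered aromatic ring of carbon only at this position and gives 1.7 nM, which hints that such a ring is compatible with low numbers, though the other differences between compound 1 and compound 3 leave the share of that ring unknown. Compound 4 is accordingly expected to move by a 6.7-fold lower number from compound 3 to compound 4 (0.82 log units; beyond the scatter), a moderate step downward, beyond the scatter. Compound 4 is estimated at 300 nM, with a range from 30 nM to 3000 nM.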

Compound 4, half-maximal effective concentration: 670 nM
For compound 4 the middle estimate is 2.2-fold (0.35 log units) below the measured one; the range from low to high includes it.
By their numbers in this assay, from the lowest: compound 1; then compound 4; then compounds 3 and 2 (each within the scatter of the next).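

The position para to a large group on the six-membered aromatic ring had shown no single-place change until now, and this first one shows that the group held there matters: in this assay the exchange of furan-3-yl for 4-cyanophenyl gives a 3.0-fold lower number from compound 3 to compound 4 (0.47 log units; beyond the scatter) with the rest of the molecule unchanged. The position therefore accepts a six-membered aromatic ring of carbon only that carries a nitrile and has more heavy atoms than the furan-3-yl group, with no rise in the number, while the count of hydrogen-bond acceptors and the lack of net charge stay as they were. No measurement at hand accounts for this step.

Going by these compounds, the ring and the nitrile enter together, so their separate shares in the step stay unknown, and a chlorine atom, a carboxylic acid or an amine in the nitrile's place would be needed to begin dividing them. On these data alone, whether a pyridine ring or a thiophene ring at this position would follow the same direction also remains open, as does whether the step would hold on a different amine side chain.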